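This account rests on a few compounds, and the source may have more. Where it says the series, first, only, none or still open, it means among the compounds named here.

Measured so far:
compound 1 `COc1ccc2c(CCCNC(C)=O)cc(=O)oc2c1` gives 3% in an assay on CHO cells for displacement of a labelled ligand from melatonin receptor type 1B (Homo sapiens), read by scintillation counting, with a stated time of 60 min, tested at 100 nM; on this read-out lower numbers stand for less inhibition and higher numbers for more inhibition at the one concentration tested (going by the name of the read-out)
compound 2 `COc1cccc2oc(=O)c(NC(C)=O)cc12` gives 0% in this assay

Compound 2 sits at one of two nearly identical readings, and compound 1 lies within the usual scatter of it, so the two cannot be told apart. Compound 3 `COc1cccc2oc(=O)c(CNC(C)=O)cc12` carries acetamidomethyl in place of acetamido on an aromatic carbon. Nothing measured here shows what such a change does, and both known readings are close to zero, so no step beyond the scatter is expected from compound 2 to compound 3. The estimated step is a number 3 percentage points higher from compound 2 to compound 3 (within the scatter). Compound 3 is expected to give about 3%, between -8% and 15%.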

Compound 3, a percentage reported as inhibition, at one concentration (the size of the read-out at that concentration, not a potency): 0.2%
The estimate for compound 3 lay 2.8 percentage points above the measured number; the measured number falls inside the stated range.
By their numbers in this assay, from the lowest: compounds 2, 3 and 1 (each within the scatter of the next).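

In this assay, acetamidomethyl in place of acetamido on this aromatic carbon gives a number 0.2 percentage points higher from compound 2 to compound 3 (within the scatter), so the two compounds cannot be told apart. Lengthening the link to the amide in this way therefore produces no detectable gain in inhibition at this position, and both compounds stay near the bottom of the read-out. Nothing available explains this outcome.

On these data alone, whether a longer chain carrying the same amide, a free amine or a carboxylic acid on this carbon would give a reading clear of the scatter remains open.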